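Allyl in place of propargyl on a shared amide core

A few compounds are considered here, and "the series" means these few. Any claim that something is new, unique, unknown or untested is made for them only; others in the source may bear on it.

Three amides share one core and differ only in the group on the aromatic ring: compound 1 `C#CCNC(=O)/C(C)=C(\C)c1ccc(OC)cc1`, compound 2 `C#CCNC(=O)/C(C)=C(\C)c1ccc(Cl)cc1` and compound 3 `C#CCNC(=O)/C(C)=C(\C)c1ccc(F)cc1`. In a toxicity assay on the whole organism (strain Icem-CET (SPF Caw)) for cytotoxicity, with Mus musculus as the target (on this read-out lower numbers stand for an effect already at smaller amounts and higher numbers for an effect only at larger amounts of compound), compound 1 gives 150 mg/kg, compound 2 gives 200 mg/kg and compound 3 gives 100 mg/kg. Compound 2 sits at the upper end of these numbers, yet nothing separates it from the others: the steps of a 1.3-fold higher number from compound 1 to compound 2 (0.12 log units; within the scatter) and a 2.0-fold lower number from compound 2 to compound 3 (0.30 log units; within the scatter) stay within the scatter, as does a 1.5-fold lower number from compound 1 to compound 3 (0.18 log units; within the scatter). Compound 4 `C=CCNC(=O)/C(C)=C(\C)c1ccc(Cl)cc1` departs from compound 2 through (vinyl in place of ethynyl on a saturated chain carbon bound to an amide-type nitrogen), propargyl becoming allyl. Going by the values given here, no measured step touches this amide-side chain; all three exchange groups on an aromatic carbon. With nothing to point either way, compound 4 is expected to show a step of no change at the digits printed from compound 2 to compound 4 (within the scatter) that stays within the scatter. The number for compound 4 is estimated at 200 mg/kg, ranging from 100 mg/kg to 400 mg/kg.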

Compound 4, dose for half-maximal effect: 70 mg/kg
Compound 4: the middle estimate sits 2.9-fold (0.46 log units) above what was measured; measured number below the stated range.
By their numbers in this assay, from the lowest: compounds 4, 3, 1 and 2 (each within the scatter of the next, the first and the last beyond it).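

The amide-side chain, which no earlier step touched, proves to matter in this assay: vinyl in place of ethynyl on a saturated chain carbon bound to an amide-type nitrogen gives a 2.9-fold lower number from compound 2 to compound 4 (0.46 log units; beyond the scatter), the only listed step beyond the scatter, whereas all three exchanges on an aromatic carbon stayed within it. Nothing available explains what lies behind this shift from propargyl to allyl. The compounds shown leave open whether the same change would act alike with methoxy or fluoro on the aromatic carbon, and how a propyl chain or a benzyl group in place of propargyl would read.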